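The source may report more compounds than this note shows. Statements on the series, on what has been measured and on what is new or still open speak of the compounds shown alone.

Measured compounds and their readings in an in vitro functional assay on HEK ts201 cells for antagonist activity at Neuronal acetylcholine receptor; alpha4/beta2 (Homo sapiens), read by fluorescence and calcium flux; on this read-out higher numbers stand for weaker inhibition and lower numbers for stronger inhibition:

Compound 1 `COc1ccc(OCCCCCN2CCCC(COC(=O)c3ccccc3N3C(=O)CC(C)C3=O)C2)cc1` gives 14500 nM.
Compound 2 `CC1CC(=O)N(c2ccccc2C(=O)OCC2CCCN(CCCCCc3ccccc3)C2)C1=O` gives 24500 nM.
Compound 3 `O=C(OCC1CCCN(CCCc2ccccc2)C1)c1ccccc1N1C(=O)CC(Cc2ccc(Cl)cc2)C1=O` gives 10700 nM.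

Compound 2 has the highest of these three numbers; compound 1 is within the scatter of it, while compound 3 lies beyond the scatter, with a lower number.

Compound 4 `COc1ccc(OCCCCCN2CCCC(COC(=O)c3ccccc3N3C(=O)CC(C)C3=O)C2)cc1OC` differs from compound 2 in one place: 3,4-dimethoxyphenoxy in place of phenyl on a saturated chain carbon, five bonds along the chain from an amine nitrogen in a ring.

Among the compounds with values here, the only measured step that bears on this change is a 1.7-fold higher number from compound 1 to compound 2 (0.23 log units; within the scatter), which exchanged 4-methoxyphenoxy for phenyl at the same place. Compound 4 reverses that exchange and adds a second methoxy. Because that step was within the scatter, the move to compound 4 is expected to be small as well: roughly a 1.8-fold lower number from compound 2 to compound 4 (0.24 log units; within the scatter), toward a lower number. Compound 4 is therefore estimated at 14000 nM, in the range 5000 nM to 35000 nM.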

Compound 4, half-maximal inhibitory concentration: 8320 nM
Compound 4: the middle estimate sits 1.7-fold (0.23 log units) above what was measured; measured number inside the range.
By their numbers in this assay, from the lowest: compounds 4, 3, 1 and 2 (each within the scatter of the next, the first and the last beyond it).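

Within the data shown here, exchanging phenyl for 3,4-dimethoxyphenoxy at this place on the chain gives the first step here that lies beyond the scatter in this assay (a 2.9-fold lower number from compound 2 to compound 4 (0.47 log units; beyond the scatter)). Adding the second methoxy alone stays within the scatter (a 1.7-fold lower number from compound 1 to compound 4 (0.24 log units; within the scatter)), so compound 1 and compound 4 cannot be ranked, and only compound 4 clearly separates from compound 2. Nothing measured here explains this step. As far as these compounds go, it remains open how much of the step belongs to the phenoxy oxygen and how much to the methoxy groups. A plain phenoxy group at this place would help to separate the two.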